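Working notes: pyridin-3-yl to pyridin-4-yl

The source may report more compounds than this note shows. Statements on the series, on what has been measured and on what is new or still open speak of the compounds shown alone.

In an ADME assay on A549 cells (Homo sapiens) for cytotoxicity, read by MTT assay, with a stated time of 72 h (a higher number here means a weaker inhibitor, a lower number a stronger inhibitor), compound 1 `Cc1ccc(C(=O)CC2(O)C(=O)Nc3ccc(Nc4ccco4)cc32)cc1` gives > 100000 nM, which is a limit of the assay and not a number. For the measured compounds named here, only two compounds have actual numbers. Compound 2 `O=C1Nc2ccc([N+](=O)[O-])cc2C1=Cc1cccnc1` gives 429000 nM, the higher of the two and so the weaker inhibitor. Compound 3 `COc1cc(/C=C2\C(=O)Nc3ccc(Nc4ccco4)cc32)cc(OC)c1OC` gives 201000 nM, a lower number by a gap beyond the usual scatter.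

The next compound to be measured is compound 4 `O=C1Nc2ccc([N+](=O)[O-])cc2C1=Cc1ccncc1`. It has the same atoms as compound 2, joined differently, with pyridin-4-yl in place of pyridin-3-yl on a double-bonded chain carbon bound to a double-bonded ring carbon.

Going by the values given here, no measured pair differs in one place only, so the size of this step cannot be read from earlier data. The expectation rests on compound 2 at 429000 nM and on the small extent of the change, and no shift beyond the scatter in this assay is expected in either direction. The estimated step of a 1.1-fold lower number from compound 2 to compound 4 (0.03 log units; within the scatter) is expected to stay within the usual scatter. For compound 4 the estimated value is 400000 nM, with an expected range of 170000 nM to 900000 nM.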

Compound 4, half-maximal inhibitory concentration: "not toxic" (no number reported)
Compound 4: no number reported, so the estimate cannot be set against anything.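

In this assay, for the compounds shown here, compound 4 is recorded only as "not toxic", with no number, so no step from compound 2 to compound 4 can be read. The compounds shown leave open whether pyridin-4-yl in place of pyridin-3-yl shifts the read-out at all, and how large any single change in this series would be.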